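Swapping the aryl group on the acetal side chain

This account rests on a few compounds, and the source may have more. Where it says the series, first, only, none or still open, it means among the compounds named here.

Of the compounds shown here, two have been measured in an assay for inhibition of Thromboxane-A synthase (Homo sapiens), using microsomes; on this read-out lower numbers stand for stronger inhibition and higher numbers for weaker inhibition. Compound 1, `O=C(O)CC/C=C\CC1COC(c2ccc([N+](=O)[O-])cc2)OC1c1cccnc1`, gives 39 nM. Compound 2, `Cc1ccc(OC(C)(C)C2OCC(C/C=C\CCC(=O)O)C(c3cccnc3)O2)cc1`, gives 360 nM, the higher of the two numbers and therefore the weaker inhibitor; the two structures differ in several places at once, so the gap between them cannot be tied to any single change.

Compound 3, `CC(C)(Oc1ccccc1[N+](=O)[O-])C1OCC(C/C=C\CCC(=O)O)C(c2cccnc2)O1`, is not yet measured. It differs from compound 2 in one place: 2-nitrophenyl in place of 4-methylphenyl on an oxygen on a saturated carbon. Within the data shown here, no measured pair shows this exact change, so its effect is open. Given that compound 1, the only compound carrying a nitro-bearing ring, gives 39 nM, a moderate drop in the number from compound 2 to compound 3 is expected, though a step within the scatter would not surprise. The expected step is a 2.4-fold lower number from compound 2 to compound 3 (0.38 log units; beyond the scatter). Compound 3 is estimated at 150 nM, within a range from 40 nM to 600 nM in this assay.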

Compound 3, half-maximal inhibitory concentration: < 10 nM
Compound 3: no number, only a limit (the forecaster's own chance of this, stated with the estimate: 0%); at least 15-fold (1.17 log units) between middle value and limit.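

The aryl group on this oxygen matters a great deal in this assay: 2-nitrophenyl in place of 4-methylphenyl gives an at least 36-fold lower number from compound 2 to compound 3 (1.55 log units; beyond the scatter), with the rest of the molecule unchanged. Until now, the gap in this series could not be tied to any single place, whereas this pair ties a large change to just one. The reading for compound 3 is a limit of the assay and not a number, and the step built on it is a minimum: the limit of < 10 nM in this assay, at which 1 of the 3 values shown sits.

This swap removes the methyl and brings in the nitro group together, and the compounds shown neither separate the two nor say how much depends on where each sits on the ring. A bare phenyl, or a ring carrying an amine or a nitrile in place of the nitro group, would test whether the nitro group itself carries the gain.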